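This account rests on a few compounds, and the source may have more. Where it says the series, first, only, none or still open, it means among the compounds named here.

Compound 1 `CCc1sc(CCc2cc(OC)cc(NCc3cc(Cl)cc(NC(=O)OC(C)C)c3)n2)nc1C` gives 234 nM in an assay on cells for binding affinity to Neuropeptide Y receptor type 1 (Homo sapiens); a lower number here means a stronger inhibitor, a higher number a weaker inhibitor. Within the data shown here, compound 2 `CCCCCCCOc1cc(CCc2nc(C)c(CC)s2)nc(NCc2cc(Cl)cc(NC(=O)OC(C)C)c2)c1` gives 72 nM in this assay, the lowest of the two numbers, and the single measured step, a 3.3-fold lower number from compound 1 to compound 2 (0.51 log units; beyond the scatter), shows what lengthening this chain did. Compound 3 `CC/C=C\CCOc1cc(CCc2nc(C)c(CC)s2)nc(NCc2cc(Cl)cc(NC(=O)OC(C)C)c2)c1` differs from compound 2 by but-1-en-1-yl in place of pentyl on a saturated chain carbon, two bonds along the chain from an oxygen on an aromatic ring, which read further out is heptyl to hex-3-en-1-yl. Since compound 2 already carries the long chain with 72 nM, only a small shift is expected, a 1.3-fold higher number from compound 2 to compound 3 (0.10 log units; within the scatter). Compound 3 is therefore estimated at 90 nM, in a range from 35 nM to 230 nM.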

Compound 3, half-maximal inhibitory concentration: 4.7 nM
The estimate for compound 3 lay 19-fold (1.28 log units) above the measured number, outside the stated range (below it).
By their numbers in this assay, from the lowest: compound 3; then compound 2; then compound 1.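

Chain length alone does not set the number at this position: going from heptyl to hex-3-en-1-yl, with one carbon fewer and a double bond, gives a 15-fold lower number from compound 2 to compound 3 (1.19 log units; beyond the scatter) in this assay. Against the methoxy compound, the same chain gives a 50-fold lower number from compound 1 to compound 3 (1.70 log units; beyond the scatter) in this assay. Nothing available explains why this change has so large an effect. The chain changes both in length and in its double bond. The two changes cannot be separated here. A saturated hexyl chain or a hex-3-yn-1-yl chain would be needed to tell them apart.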